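Urea arm swap on compound 2: a working estimate

The source may hold more compounds than are shown below. What is called first, only, known or untested is meant among the compounds shown, and "the series" means these compounds.

- compound 1 `O=C(NC1CCCCC1)N1CCN(c2nc(-c3ccc4ccccc4n3)no2)CC1` in a functional assay on Shh Light II cells (Mus musculus) for inhibition, read by a luciferase reporter; a lower number here means a stronger inhibitor, a higher number a weaker inhibitor: 53 nM
- compound 2 `O=C(Nc1ccccc1Cl)N1CCC(c2nc(-c3ccc4ccccc4n3)no2)CC1`: 510 nM
- compound 3 `O=C(N1CCC(c2nc(-c3ccc4ccccc4n3)no2)CC1)N1CCCc2ccccc21`: 2300 nM

Compound 2, at 510 nM, holds the second highest of the three numbers, with compound 1 lower and compound 3 higher. Compound 4 `O=C(NC1CCC(O)CC1)N1CCC(c2nc(-c3ccc4ccccc4n3)no2)CC1` is not yet measured. It carries 4-hydroxycyclohexyl in place of 2-chlorophenyl on an amide-type nitrogen.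

Within the data shown here, the only measured step touching this part of compound 2 is a 4.5-fold higher number from compound 2 to compound 3 (0.65 log units; beyond the scatter), which is modest. Compound 1, at 53 nM, also carries a non-aromatic ring of carbon only on its amide-type nitrogen, but it differs elsewhere too, so it offers only a weak lean towards lower numbers. A step of no more than modest size is therefore expected in this assay, its direction uncertain. The estimate is a 1.3-fold lower number from compound 2 to compound 4 (0.11 log units; within the scatter). Compound 4 is estimated at 400 nM, with an expected range of 100 nM to 1800 nM.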

Compound 4, half-maximal inhibitory concentration: 2700 nM
Compound 4: the middle estimate sits 6.8-fold (0.83 log units) below what was measured; measured number outside the range, above it.
By their numbers in this assay, from the lowest: compound 1; then compound 2; then compounds 3 and 4 (each within the scatter of the next).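

In this assay, a 5.3-fold higher number from compound 2 to compound 4 (0.72 log units; beyond the scatter) shows that 4-hydroxycyclohexyl on this amide-type nitrogen does not match 2-chlorophenyl, so a second, quite different replacement also gives a higher number. With a 1.2-fold higher number from compound 3 to compound 4 (0.07 log units; within the scatter), compounds 3 and 4 cannot be told apart, and compound 2 remains the lowest of these three. Nothing available explains the rise in compound 4.

Still open, on these data alone, is how plain phenyl on this nitrogen would compare, which would test the chlorine alone. A 4-methoxycyclohexyl group would likewise test the hydroxyl hydrogen.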